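Lengthening the Ester Chain of a Gastric Inhibitor

This account rests on a few compounds, and the source may have more. Where it says the series, first, only, none or still open, it means among the compounds named here.

Compound 3 `CC(=O)OCc1c(C)nc2c(OCc3ccccc3)cccn12` is the strongest of three compounds measured in a functional assay on the whole organism (stomach) for inhibition, with Canis familiaris (Canis lupus familiaris) as the target, at a dose of 5 mg/kg by the intravenous route (on this read-out higher numbers stand for a stronger effect at the one dose given and lower numbers for a weaker effect), where compound 3 gives 87%. Compound 1 `CSCc1c(C)nc2c(OCc3ccccc3)cccn12` gives 8% and compound 2 `Cc1nc2c(OCc3ccccc3)cccn2c1Br` gives 63%. The steps of a number 79 percentage points higher from compound 1 to compound 3 (beyond the scatter) and a number 24 percentage points higher from compound 2 to compound 3 (beyond the scatter) are both beyond the scatter, as is a number 55 percentage points higher from compound 1 to compound 2 (beyond the scatter). Compound 4 `CCCCC(=O)OCc1c(C)nc2c(OCc3ccccc3)cccn12` keeps the acetoxy side of compound 3 and differs only by propyl in place of hydrogen on a saturated chain carbon bound to a carbonyl carbon. Among the compounds with values here, none of the measured steps touches this chain; each exchanges the whole group on the aromatic carbon, so they offer no direct guide. Within the data shown here, with no bearing step, the change is expected to be small, a number 7 percentage points lower from compound 3 to compound 4 (within the scatter), within the scatter. Compound 4 is therefore estimated at 80%, between 55% and 95%.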

Compound 4, a percentage reported as inhibition, in the whole organism at one dose (the size of the read-out at that dose, not a potency): 96%
Compound 4: middle estimate off by 16 percentage points, on the low side; the measured number lies above the stated range.
By their numbers in this assay, from the lowest: compound 1; then compound 2; then compounds 3 and 4 (each within the scatter of the next).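

In this assay, lengthening acetoxy to (butylcarbonyl)oxy gives no change that stands out from the scatter (a number 9 percentage points higher from compound 3 to compound 4 (within the scatter)), so this saturated chain carbon takes a propyl without a detectable loss of effect. Compound 4 also keeps the ester's clear advantage over bromo (a number 33 percentage points higher from compound 2 to compound 4 (beyond the scatter)) and over the methylsulfanyl group (a number 88 percentage points higher from compound 1 to compound 4 (beyond the scatter)). Nothing available explains why the ester compounds give these higher numbers. As far as these compounds go, whether a longer chain on the ester, or an amine at this same carbon, would keep the effect remains open. A single dose also shows only the size of the effect of compound 3 and compound 4 at that dose, and whether their effects would differ at any other dose remains unresolved.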